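The compounds below may be only part of what the source reports. "The series", "measured", "known", "first", "only" and "open" are said of these compounds alone.

Compound 1 `Cc1ccccc1Nc1nc(C)c(C(=O)/C=C/c2ccc(Cl)cc2)s1`, compound 2 `Cc1nc(Nc2ccc(Cl)cc2)sc1C(=O)/C=C/c1ccc(Cl)cc1` and compound 3 `COc1cc(/C=C/C(=O)c2sc(Nc3ccccc3)nc2C)cc(OC)c1OC` share one core and differ only in the group on the anilino nitrogen or on the far phenyl ring. In a functional assay on Bel-7402 cells (Homo sapiens) for cytotoxicity, read by MTT assay (on this read-out higher numbers stand for weaker inhibition and lower numbers for stronger inhibition), compound 1 gives > 25000 nM, which is a limit of the assay and not a number. Compound 2 gives > 25000 nM in this assay, again a limit rather than a measured number. Compound 3 likewise gives > 25000 nM in this assay, once more a limit. All three values therefore sit at the same point, (the limit of > 25000 nM in this assay, at which 3 of the 3 values shown sit), and compound 3 stands nowhere more precise than that limit.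

Among the compounds with values here, the one step between neighbours, from compound 1 to compound 2, reads a step that the two limits leave unreadable from compound 1 to compound 2, so its size cannot be known. Compound 4 `COc1cc(/C=C/C(=O)c2sc(Nc3cccc(C)c3)nc2C)cc(OC)c1OC` differs from compound 3 by methyl in place of hydrogen on an aromatic carbon. The measured step also concerns the anilino group, yet it gives no readable size, so no step beyond the scatter is expected: a step that the limit leaves unreadable from compound 3 to compound 4. Compound 4 is therefore estimated at 30000 nM, expected to fall between 10000 nM and 100000 nM, most likely again as a limit.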

Compound 4, half-maximal inhibitory concentration: > 25000 nM
Compound 4: a limit, no number; the forecaster's own chance of this, stated with the estimate: 80%; the middle value is on the limit's open side.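

No new step can be read from compound 3 to compound 4, since both values are limits and not numbers: the limit of > 25000 nM in this assay, at which 4 of the 4 values shown sit.

The compounds shown leave open how strongly any of them acts in this assay, and which change to the shared core, if any, would give a measurable number.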